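Methoxy substitution on the benzodioxin series: compound 3 to 4

The source may hold more compounds than are shown below. What is called first, only, known or untested is meant among the compounds shown, and "the series" means these compounds.

Of the compounds shown here, three have been measured in an assay (Ovis aries) for binding affinity to melatonin receptor type 1A (Homo sapiens); on this read-out higher numbers stand for weaker inhibition and lower numbers for stronger inhibition. Compound 1 `CC(=O)NCCn1ccc2cccnc21` gives 10000 nM in this assay. Compound 2 `CC(=O)NCCCCc1cccc2c1SCCO2` gives 126 nM in this assay, the lowest number in the set, with its gaps to both other compounds beyond the scatter. Compound 3 `CC(=O)NCC1=C(c2ccccc2)Oc2ccccc2O1` gives 31600 nM in this assay, the highest of the three numbers; the nearest value is that of compound 1, the furthest that of compound 2, and both separations lie beyond the scatter.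

Compound 4 `COc1ccc2c(c1)OC(CNC(C)=O)=C(c1ccccc1)O2` has not yet been measured. It differs from compound 3 in one place: methoxy in place of hydrogen on an aromatic carbon, on a six-membered aromatic ring of carbon only within a fused system of two rings. Among the compounds with values here, no measured pair in the set shows this change, so its size is not known from the data.

The expectation is a step downward in this assay from compound 3 to compound 4, an 11-fold lower number from compound 3 to compound 4 (1.02 log units; beyond the scatter), beyond the scatter but uncertain in size. Compound 4 is estimated at 3000 nM, with a range from 500 nM to 20000 nM.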

Compound 4, half-maximal inhibitory concentration: 10000 nM
Estimate against measurement, compound 4: 3.3-fold (0.52 log units) below; the measured number falls inside the stated range.
By their numbers in this assay, from the lowest: compound 2; then compounds 1 and 4 (each within the scatter of the next); then compound 3.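

In this assay, within the data shown here, methoxy in place of hydrogen on an aromatic carbon gives a 3.2-fold lower number from compound 3 to compound 4 (0.50 log units; beyond the scatter), a modest step but beyond the scatter, and the first measured pair in the set to show this change. It shows that this place on the six-membered aromatic ring of carbon only, meta to a fused ring and para to a fused ring, accepts methoxy with a lower number rather than a higher one, although compound 4 still reads 10000 nM and this single step does not bring the number into the range of low values. Nothing available explains the direction or the size of this step.

Still open, going by these compounds, is whether the step belongs to methoxy itself or to any group at this place, a question that hydroxy, ethoxy or an amine on the same aromatic carbon would address. Also open, on these data alone, is whether methoxy on the other aromatic carbons of this ring gives a step of similar size, and whether the step holds when the phenyl group of the shared core is replaced by a smaller group such as methyl.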